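This account rests on a few compounds, and the source may have more. Where it says the series, first, only, none or still open, it means among the compounds named here.

Measured in a functional assay on HEY cells (Homo sapiens) for cytotoxicity, read by MTT assay, with a stated time of 72 h; a lower number here means a stronger inhibitor, a higher number a weaker inhibitor:

Compound 1, `COc1ccc(CNC(=O)c2nc(Br)c3cccnc3c2N[C@H]2CC[C@H](N)CC2)cc1`: 4000 nM
Compound 2, `CN(C)c1ccc(CNC(=O)c2nc(Br)c3cccnc3c2N[C@H]2CC[C@H](N)CC2)cc1`: 5300 nM
Compound 3, `N[C@H]1CC[C@H](Nc2c(C(=O)NCc3cccs3)nc(Br)c3cccnc23)CC1`: 11000 nM

Compound 1 gives the lowest of the three numbers; compound 2 sits within the scatter of it, while compound 3 lies furthest away. The step of a 1.3-fold higher number from compound 1 to compound 2 (0.12 log units; within the scatter), dimethylamino in place of methoxy on an aromatic carbon, barely moves the reading. The steps of a 2.8-fold higher number from compound 1 to compound 3 (0.44 log units; beyond the scatter) and a 2.1-fold higher number from compound 2 to compound 3 (0.32 log units; beyond the scatter), each putting thiophen-2-yl in place of the aryl group on the saturated chain carbon bound to the amide-type nitrogen, both weaken the compound modestly.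

Compound 4, `N[C@H]1CC[C@H](Nc2c(C(=O)Nc3ccccc3)nc(Br)c3cccnc23)CC1`, differs from compound 1 by phenyl in place of 4-methoxybenzyl on an amide-type nitrogen. Going by the values given here, no measured step removes that saturated chain carbon, so the only guidance is that swaps of the group carried on the amide nitrogen have so far cost a modest amount of potency in this assay, as seen in compound 3. A modest weakening is therefore expected here too. Compound 4 is expected to give 8000 nM, within the range 2500 nM to 25000 nM. The expected step for compound 4 is a 2.0-fold higher number from compound 1 to compound 4 (0.30 log units; within the scatter).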

Compound 4, half-maximal inhibitory concentration: 1000 nM
Estimate against measurement, compound 4: 8.0-fold (0.90 log units) above; the whole stated range lies above it.
By their numbers in this assay, from the lowest: compound 4; then compounds 1 and 2 (each within the scatter of the next); then compound 3.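

In this assay, compound 4 is the only compound shown with an aromatic ring directly on the amide-type nitrogen, with no saturated chain carbon, and it gives a lower number than each of the others: a 4.0-fold lower number from compound 1 to compound 4 (0.60 log units; beyond the scatter) and a 5.3-fold lower number from compound 2 to compound 4 (0.72 log units; beyond the scatter), while the largest step is an 11-fold lower number from compound 3 to compound 4 (1.04 log units; beyond the scatter). Changes at this position can therefore strengthen the compound as well as weaken it, which the earlier steps did not show, as they were either within the scatter or moved to a higher number. Nothing in the data shown accounts for this gain.

As far as these compounds go, the step to compound 4 removes the saturated chain carbon and the methoxy group together, so their separate contributions remain unknown. An unsubstituted benzyl group, a 4-methoxyphenyl group or a longer chain such as 2-phenylethyl on the same nitrogen would help to separate them.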